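From naphthalen-1-yl to 4-carbamoylphenyl at the assay limit

A few compounds are considered here, and "the series" means these few. Any claim that something is new, unique, unknown or untested is made for them only; others in the source may bear on it.

Compound 1 (`Cc1cc(Cc2cccc(F)c2)c(=O)n(CC(=O)Nc2ccc(Br)cc2)n1`) gives > 50000 nM in a functional assay on HL-60 cells (Homo sapiens), read by calcium flux (on this read-out higher numbers stand for an effect only at larger amounts of compound and lower numbers for an effect already at smaller amounts), as a limit of the assay and not a number. Compound 2 (`COc1cc(Cc2cc(C)nn(CC(=O)Nc3ccc(Br)cc3)c2=O)cc(OC)c1`) gives > 50000 nM in this assay as a limit too. Compound 3 (`Cc1cc(Cc2cccc3ccccc23)c(=O)n(CC(=O)Nc2ccc(Br)cc2)n1`) stands at > 50000 nM in this assay and this is again a limit. Compound 4 (`Cc1cc(Cc2ccc(C(N)=O)cc2)c(=O)n(CC(=O)Nc2ccc(Br)cc2)n1`) has 4-carbamoylphenyl in place of naphthalen-1-yl on a saturated chain carbon bound to an aromatic carbon. Three measured steps at that place bear on this change. These are a step that the two limits leave unreadable from compound 1 to compound 2 and a step that the two limits leave unreadable from compound 1 to compound 3 and also a step that the two limits leave unreadable from compound 2 to compound 3 and none of them has a readable size. Since the limit of > 50000 nM in this assay, at which 3 of the 3 values shown sit, is all the evidence available, no step beyond the scatter and no direction is expected, and the estimated change is a number no higher from compound 3 to compound 4 (the limit leaves the size open) for now. Compound 4 is estimated at 50000 nM in this assay with an expected range from 20000 nM to 100000 nM on this read-out.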

Compound 4, half-maximal effective concentration: > 50000 nM
Compound 4: no number, only a limit (the forecaster's own chance of this, stated with the estimate: 80%); the middle value lies on the limit itself.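

In this assay compound 4 gives > 50000 nM, a limit of the assay and not a number. Its steps from compound 1, compound 2 and compound 3 therefore cannot be read. The compounds shown leave open which group on that saturated chain carbon, if any, would give a readable value in this assay.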